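The source may report more compounds than this note shows. Statements on the series, on what has been measured and on what is new or still open speak of the compounds shown alone.

Within the data shown here, compound 1 `CCC(C)(C)Cc1c[nH]c(CCc2ccc(-c3ccncc3)cc2)n1` gives 101 nM in an in vitro assay on CHO cells for displacement of a labelled ligand from Bombesin receptor subtype-3 (Homo sapiens), read by scintillation counting, with a stated time of 2 h (on this read-out higher numbers stand for weaker inhibition and lower numbers for stronger inhibition), the highest of the three numbers measured so far. Compound 2 `CCC(C)(C)Cc1c[nH]c(CCc2ccc(-c3csnn3)cc2)n1` gives 45 nM, a change of a 2.2-fold lower number from compound 1 to compound 2 (0.35 log units; beyond the scatter). Compound 3 `CCC(C)(C)Cc1c[nH]c(CCc2ccc(-c3cccnc3)cc2)n1` gives 7.5 nM, a change of a 13-fold lower number from compound 1 to compound 3 (1.13 log units; beyond the scatter); between these two stands a 6.0-fold lower number from compound 2 to compound 3 (0.78 log units; beyond the scatter). Compound 4 `CCC(C)(C)Cc1c[nH]c(CCc2ccc(-n3ncnn3)cc2)n1` differs from compound 1 by 2H-tetrazol-2-yl in place of pyridin-4-yl on an aromatic carbon. The nearest precedent is compound 2, where a five-membered aromatic ring with hetero atoms also replaced pyridin-4-yl and the number fell modestly, as shown by a 2.2-fold lower number from compound 1 to compound 2 (0.35 log units; beyond the scatter); the larger fall to compound 3, a 13-fold lower number from compound 1 to compound 3 (1.13 log units; beyond the scatter), kept a six-membered ring and is less comparable. A modest fall beyond the scatter is therefore expected for compound 4, not the size seen for compound 3. Compound 4 is estimated at 40 nM, between 15 nM and 120 nM, an expected step of a 2.5-fold lower number from compound 1 to compound 4 (0.40 log units; beyond the scatter).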

Compound 4, half-maximal inhibitory concentration: 205 nM
Compound 4: middle estimate off by 5.1-fold (0.71 log units), on the low side, and the stated range ends below it.
By their numbers in this assay, from the lowest: compound 3; then compound 2; then compound 1; then compound 4.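

In this assay, among these compounds, the 2H-tetrazol-2-yl group is the first replacement of pyridin-4-yl at this position, para to a large group, to raise the number, with a 2.0-fold higher number from compound 1 to compound 4 (0.31 log units; beyond the scatter) as the step. A five-membered aromatic ring therefore does not lower the number by itself: a 4.6-fold higher number from compound 2 to compound 4 (0.66 log units; beyond the scatter) separates two such rings, and a 27-fold higher number from compound 3 to compound 4 (1.44 log units; beyond the scatter) is the widest gap in the series. No supporting data explain these differences. Open, from the compounds shown here alone, is how an amine or a carboxylic acid on the pyridin-3-yl ring of compound 3 would read in this assay here.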